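A few compounds are considered here, and "the series" means these few. Any claim that something is new, unique, unknown or untested is made for them only; others in the source may bear on it.

Measured compounds:
compound 1, `O=C1C=CC(=O)N1c1cc(C(F)(F)F)cc(C(F)(F)F)c1`, < 0.017 h in an ADME assay for pharmacokinetics, read by LC-MS, in phosphate buffer, with a stated time of 72 h, at pH 7.4, tested at 250 uM (on this read-out higher numbers stand for a longer-lived compound and lower numbers for a shorter-lived compound), a limit of this assay;
compound 2, `N#Cc1cc(C(F)(F)F)cc(C(F)(F)F)c1`, > 50 h in this assay, also a limit.

Compound 2 stands at the upper limit of this assay, so its value is a bound rather than a number. Of compound 1 only a lower bound is known, at the other end of the range. Among the measured compounds shown here, the one measured step, an at least 2900-fold higher number from compound 1 to compound 2 (3.46 log units; beyond the scatter), is therefore itself a bound, with both ends resting on limits: the limit of < 0.017 h in this assay, at which 1 of the 2 values shown sits, and (the limit of > 50 h in this assay, at which 1 of the 2 values shown sits).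

Compound 3, `FC(F)(F)c1cc(C2CO2)cc(C(F)(F)F)c1`, has not been measured. It differs from compound 2 in one place: oxiran-2-yl in place of cyano on an aromatic carbon. For the measured compounds named here, no measured step exchanges a cyano for a three-membered ring, so the large step from compound 1 to compound 2 bears on it only as a sign that this position can move the read-out across the whole range. Compound 3 is expected to give 30 h, within 3 h to 300 h. That estimate means an at least 1.6-fold lower number from compound 2 to compound 3 (0.22 log units; that floor lies within the scatter), and a reported limit rather than a number is expected to be a real possibility.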

Compound 3, half-life: > 50 h
Compound 3: no number, only a limit; the forecaster's own chance of this, stated with the estimate: 40%; middle value at least 1.6-fold (0.22 log units) from the limit.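

Compound 3 sits with compound 2 at the top of this assay, so at this position on the shared core a second group, oxiran-2-yl as well as cyano, leaves the read-out at a limit: the limit of > 50 h in this assay, at which 2 of the 3 values shown sit. Putting oxiran-2-yl on this aromatic carbon in place of the five-membered ring gives an at least 2900-fold higher number from compound 1 to compound 3 (3.46 log units; beyond the scatter), again a bound with both ends resting on limits, so the large step seen earlier does not belong to the nitrile alone. The step between cyano and oxiran-2-yl cannot be read, since both of its ends are limits, and the two groups therefore cannot be ranked against each other.

The compounds shown leave open which feature of the group in compound 1 goes with its place at the lower limit, as they offer only a single group at that end of the range. They also leave open whether a succinimide, an open-chain amide or an amine on this aromatic carbon would give a true number between the two limits.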